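A few compounds are considered here, and "the series" means these few. Any claim that something is new, unique, unknown or untested is made for them only; others in the source may bear on it.

Values in an ADME assay on KB cells (Homo sapiens) for cytotoxicity (on this read-out higher numbers stand for an effect only at larger amounts of compound and lower numbers for an effect already at smaller amounts), for the measured compounds:
- compound 1 `CCOC(=O)N1[C@@H]2C=C[C@@](OC)(C(=O)c3c2cc(OC)c(OC)c3OCc2ccc(F)cc2)N1C(=O)OCC` with 51.8 ug/mL
- compound 2 `CCOC(=O)N1[C@@H]2C=C[C@@](OC)(C(=O)c3c2cc(OC)c(OC)c3OCC)N1C(=O)OCC` with > 300 ug/mL as a limit of the assay
- compound 3 `CCOC(=O)N1[C@@H]2C=C[C@@](OC)(C(=O)c3c2cc(OC)c(OC)c3OCc2ccccc2F)N1C(=O)OCC` with 99.7 ug/mL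

Compound 3 lies level with compound 1 within the scatter (a 1.9-fold higher number from compound 1 to compound 3 (0.28 log units; within the scatter)). Compound 4 `CCCCOc1c(OC)c(OC)cc2c1C(=O)[C@]1(OC)C=C[C@H]2N(C(=O)OCC)N1C(=O)OCC` differs from compound 3 by propyl in place of 2-fluorophenyl on a saturated chain carbon bound to an oxygen on an aromatic ring. The closest guides are the two steps that swap an aromatic ring for methyl at this place (an at least 5.7-fold higher number from compound 1 to compound 2 (0.76 log units; beyond the scatter) and an at least 3.0-fold lower number from compound 2 to compound 3 (0.47 log units; beyond the scatter)) and both lie beyond the scatter. Both rest on the limit of > 300 ug/mL in this assay, at which 1 of the 3 values shown sits, and so give only minimum sizes. A modest step to a higher number is therefore expected (a 2.2-fold higher number from compound 3 to compound 4 (0.34 log units; beyond the scatter)). Compound 4 is estimated at 220 ug/mL (estimated range 90 ug/mL to 450 ug/mL).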

Compound 4, concentration for half-maximal effect: 76 ug/mL
The estimate for compound 4 lay 2.9-fold (0.46 log units) above the measured number, and the stated range ends above it.
By their numbers in this assay, from the lowest: compounds 1, 4 and 3 (each within the scatter of the next). At a limit, above all of these: compound 2.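

In this assay, an aromatic ring at this place proves unnecessary for staying level with the fluorophenyl compounds, with a 1.3-fold lower number from compound 3 to compound 4 (0.12 log units; within the scatter) and a 1.5-fold higher number from compound 1 to compound 4 (0.17 log units; within the scatter). Ethyl in place of hydrogen on the saturated chain carbon, two bonds along the chain from the oxygen on the aromatic ring, gives an at least 3.9-fold lower number from compound 2 to compound 4 (0.59 log units; beyond the scatter), so a purely aliphatic chain can also produce a step beyond the scatter. The value of compound 2 is a limit, and this step gives only a minimum size: the limit of > 300 ug/mL in this assay, at which 1 of the 4 values shown sits.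

On these data alone, it remains open whether a longer chain would stay level with compound 4, and how an amine or a carboxylic acid at the chain end would read.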